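Amide variation at the carbonyl: from compound 2 to compound 3

This account rests on a few compounds, and the source may have more. Where it says the series, first, only, none or still open, it means among the compounds named here.

Measured so far:
compound 1 `CSc1nc(-c2cccc(O)c2)c2c(N)c(C(=O)NC(C)(C)C)sc2n1`: 63.9%
compound 2 `COc1cccc(-c2nc(SC)nc3sc(C(=O)NN)c(N)c23)c1`: 8.5%

Both compounds were tested in a functional assay on HEK293 cells for agonist activity at lutropin-choriogonadotropic hormone receptor (Homo sapiens), read by cAMP accumulation; a higher number here means a larger maximal response, a lower number a smaller maximal response. Compound 1 gives 63.9% there, while compound 2 gives 8.5%, the lowest of the two numbers; the gap to compound 1 lies beyond the usual scatter of repeated measurements. The two structures differ in several places at once, so no single change can be read off from them.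

Compound 3 `COc1cccc(-c2nc(SC)nc3sc(C(=O)N(C)C)c(N)c23)c1` differs from compound 2 in one place only: dimethylamino in place of aminoamino on a carbonyl carbon. The group that leaves carries hydrogen-bond donors and an acceptor; the group that enters carries none. For the measured compounds named here, compound 1, the only other measured compound, bears a different amide again, so its value gives no direct guide for this change.

The step from compound 2 to compound 3 is expected to be an increase in maximal response, a number 16.5 percentage points higher from compound 2 to compound 3 (beyond the scatter), though with wide uncertainty. Compound 3 is therefore estimated at 25%, within a range from 5% to 60%.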

Compound 3, largest response reached (reported as efficacy), in percent of the reference or control that the assay uses: 11%
Compound 3: the middle estimate sits 14 percentage points above what was measured; the measured number falls inside the stated range.
By their numbers in this assay, from the lowest: compounds 2 and 3 (each within the scatter of the next); then compound 1.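

In this assay, placing dimethylamino instead of aminoamino on the carbonyl carbon gives a number 2.5 percentage points higher from compound 2 to compound 3 (within the scatter), so this pair cannot be told apart. The group that leaves carries hydrogen-bond donors and an acceptor, whereas the group that enters carries none, so losing these donors and this acceptor at this position, on this core, brings no change in maximal response beyond the scatter. No measurement shown here offers an explanation for this result.

Compound 1, at 63.9%, differs from both compounds in several places, so the part played by its amide cannot be read from these data. From the compounds shown here alone, it remains open whether a carboxylic acid or a longer chain, such as diethylamino, on this carbonyl carbon would move the response beyond the scatter.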